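A methyl added to compound 2

The source may hold more compounds than are shown below. What is called first, only, known or untested is meant among the compounds shown, and "the series" means these compounds.

Compound 1 `Cc1ccc(Nc2c(NCCCCCC(=O)NO)c(=O)c2=O)cc1` gives 1800000 nM
Compound 2 `CC(CCCCC(=O)NO)Nc1c(Nc2ccccc2)c(=O)c1=O` gives 46000000 nM

In a physicochemical assay for solubility, with a stated time of 24 h, tested at 30 mg/mL (on this read-out higher numbers stand for higher solubility and lower numbers for lower solubility), compound 2 reads 46000000 nM and holds the higher of the two numbers, well beyond the scatter from compound 1. Compound 3 `Cc1ccc(Nc2c(NC(C)CCCCC(=O)NO)c(=O)c2=O)cc1` differs from compound 2 by methyl in place of hydrogen on an aromatic carbon in one place, methyl in place of hydrogen on an aromatic carbon. Among the measured compounds shown here, no single-change step has been measured, and compound 1, which also carries 4-methylphenyl, gives 1800000 nM as the only guide. The expected change a 3.8-fold lower number from compound 2 to compound 3 (0.58 log units; beyond the scatter) is a downward step beyond the scatter. For compound 3 the estimated value is 12000000 nM with 3000000 nM to 40000000 nM as its range.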

Compound 3, solubility: 4900000 nM
The estimate for compound 3 lay 2.4-fold (0.39 log units) above the measured number, within the range that was stated.
By their numbers in this assay, from the lowest: compound 1; then compound 3; then compound 2.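

In this assay, methyl in place of hydrogen on an aromatic carbon, para to a large group, now has a measured size: a 9.4-fold lower number from compound 2 to compound 3 (0.97 log units; beyond the scatter). Methyl in place of hydrogen on the saturated chain carbon bound to the nitrogen gives a 2.7-fold higher number from compound 1 to compound 3 (0.43 log units; beyond the scatter), so the two methyl changes run in opposite directions on this read-out. Nothing shown accounts for either step. On these data alone, whether a methoxy group or a chlorine at the same place would move the number the same way stays open, as does whether phenyl to 4-methylphenyl gives a similar step with a longer chain.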